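Series notes: adding a second methoxy to compound 3

The source may hold more compounds than are shown below. What is called first, only, known or untested is meant among the compounds shown, and "the series" means these compounds.

Values in a functional assay on U-87MG ATCC cells for antiproliferative activity against U-87 MG (Homo sapiens), read by MTT assay, with a stated time of 48 h; on this read-out lower numbers stand for stronger inhibition and higher numbers for weaker inhibition:
- compound 1 `COc1ccc(-c2nc(C)c(C(=O)CSc3nc(-c4ccc(Cl)cc4)c(C#N)c(=O)[nH]3)s2)cc1`: 45900 nM
- compound 2 `COc1ccc(-c2nc(C)c(C(=O)CSc3nc(-c4ccc(OC)cc4)c(C#N)c(=O)[nH]3)s2)cc1`: 25300 nM
- compound 3 `COc1ccc(-c2nc(C)c(C(=O)CSc3nc(-c4cccc(OC)c4)c(C#N)c(=O)[nH]3)s2)cc1`: 15300 nM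

Compound 3 stands level with compound 2 within the usual scatter, as shown by a 1.7-fold lower number from compound 2 to compound 3 (0.22 log units; within the scatter). Against the other end of this small set, the gap is a 3.0-fold lower number from compound 1 to compound 3 (0.48 log units; beyond the scatter). The remaining step is a 1.8-fold lower number from compound 1 to compound 2 (0.26 log units; within the scatter).

Next is compound 4 `COc1ccc(-c2nc(C)c(C(=O)CSc3nc(-c4ccc(OC)c(OC)c4)c(C#N)c(=O)[nH]3)s2)cc1`, which is unmeasured. The change is methoxy in place of hydrogen on an aromatic carbon, ortho to a methoxy group and para to a large group, turning 3-methoxyphenyl into 3,4-dimethoxyphenyl.

For the measured compounds named here, no measured step adds a second methoxy to this ring, so the evidence is indirect. The new ring holds the 3-methoxyphenyl of compound 3 and the 4-methoxyphenyl of compound 2, and exchanging those two groups gave only a 1.7-fold lower number from compound 2 to compound 3 (0.22 log units; within the scatter). Little movement is therefore expected in this assay, with no clear direction and nothing beyond the scatter. The expected step is a 1.1-fold higher number from compound 3 to compound 4 (0.05 log units; within the scatter). For compound 4 the estimated value is 17000 nM, with an expected range of 7500 nM to 38000 nM.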

Compound 4, half-maximal inhibitory concentration: 12500 nM
Estimate against measurement, compound 4: 1.4-fold (0.13 log units) above, and the stated range covers the measured number.
By their numbers in this assay, from the lowest: compounds 4, 3, 2 and 1 (each within the scatter of the next, the first and the last beyond it).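

In this assay the methoxy entering the 3-methoxyphenyl ring, ortho to a methoxy group and para to a large group, leaves compound 4 level with compound 3 (a 1.2-fold lower number from compound 3 to compound 4 (0.09 log units; within the scatter)), so this position accepts the added group without a shift that can be told from the scatter. For the compounds shown here, the same 3,4-dimethoxyphenyl ring, read as methoxy added to the 4-methoxyphenyl ring, gives a modest gain that clears the scatter (a 2.0-fold lower number from compound 2 to compound 4 (0.31 log units; beyond the scatter)), whereas the exchange of the single methoxy between compound 2 and compound 3 did not clear it. Against the 4-chlorophenyl ring the gap is also modest and is the widest step in this small set (a 3.7-fold lower number from compound 1 to compound 4 (0.56 log units; beyond the scatter)), which extends the earlier difference from compound 1 without changing its scale.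

No measurement shown here gives a reason for any of these steps. Still open, on these data alone, is whether a different group at this position of the ring, such as an amine, a carboxylic acid or a longer chain like ethoxy, would move the number beyond the scatter from compound 4.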